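A methoxy group enters the phenyl of compound 2

The source may hold more compounds than are shown below. What is called first, only, known or untested is meant among the compounds shown, and "the series" means these compounds.

Among the compounds with values here, compound 2 `O=C1c2ccccc2S(=O)(=O)N1CCCCCN1CCN(c2ccccc2)CC1` gives 1840 nM in an assay on HEK293 cells for displacement of a labelled ligand from 5-hydroxytryptamine receptor 6 (Homo sapiens) (a higher number here means a weaker inhibitor, a lower number a stronger inhibitor), the highest of the two numbers measured so far; its nearest neighbour is compound 1 `O=C1c2ccccc2S(=O)(=O)N1CCCCCN1CCN(c2ccc(Cl)cc2)CC1`, which in this assay gives 703 nM. Within the data shown here, the single measured step, a 2.6-fold higher number from compound 1 to compound 2 (0.42 log units; beyond the scatter), put hydrogen in place of chloro on an aromatic carbon. Compound 3 `COc1ccccc1N1CCN(CCCCCN2C(=O)c3ccccc3S2(=O)=O)CC1` carries the change (methoxy in place of hydrogen on an aromatic carbon). Among the measured compounds shown here, no measured step involves a methoxy group, but compound 1 shows that a substituent on that ring can lower the number, as a 2.6-fold higher number from compound 1 to compound 2 (0.42 log units; beyond the scatter) read in reverse. Compound 3 is therefore expected to move a 2.6-fold lower number from compound 2 to compound 3 (0.42 log units; beyond the scatter), with an estimate of 700 nM and a range from 200 nM to 2500 nM.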

Compound 3, inhibition constant: 1990 nM
Estimate against measurement, compound 3: 2.8-fold (0.45 log units) below; measured number inside the range.
By their numbers in this assay, from the lowest: compound 1; then compounds 2 and 3 (each within the scatter of the next).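

In this assay, methoxy on an aromatic carbon ortho to a large group gives no change beyond the scatter (a 1.1-fold higher number from compound 2 to compound 3 (0.03 log units; within the scatter)), so this substitution does not reproduce the lower number seen with the 4-chlorophenyl of compound 1. Replacing 4-chlorophenyl with 2-methoxyphenyl gives a step beyond the scatter (a 2.8-fold higher number from compound 1 to compound 3 (0.45 log units; beyond the scatter)), but that step changes both the group and its place on the ring, so the two cannot be separated. No evidence bears on this result. The compounds shown leave open whether a fluoro group or an amine on that same aromatic carbon would shift the number.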